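Shortening the chain between the diketo amide and phenyl

The source may report more compounds than this note shows. Statements on the series, on what has been measured and on what is new or still open speak of the compounds shown alone.

compound 1 `O=C(CCCCCCc1ccccc1)N[C@H]1CCOC1=O` — in a functional assay on NCI-H630 cells (Homo sapiens) for cytotoxicity, read by sulforhodamine B assay, with a stated time of 5 days (a higher number here means a weaker inhibitor, a lower number a stronger inhibitor), gives > 100000 nM, which is a limit, not a number
compound 2 `O=C(CCCCCCCCCCc1ccccc1)CC(=O)N[C@H]1CCOC1=O` — in this assay gives 14000 nM

Going by the values given here, compound 2 carries the only numerical value shown in this assay; the other entry is the limit of > 100000 nM in this assay, at which 1 of the 2 values shown sits. Compound 1 sits at that limit, so its result is a bound rather than a measurement. Compound 3 `O=C(CCCCCCCCc1ccccc1)CC(=O)N[C@H]1CCOC1=O` differs from compound 2 in one place: phenyl in place of phenethyl on a saturated chain carbon, eight bonds along the chain from a carbonyl carbon. Among the compounds with values here, no step between two measured compounds is available here, so the size of this change can only be expected, not read off. Compound 3 keeps the core of compound 2 but with a shorter chain to the aromatic ring, and a modest weakening is expected, with a 1.8-fold higher number from compound 2 to compound 3 (0.25 log units; within the scatter) likely close to or a little beyond the scatter. Compound 3 is therefore estimated at 25000 nM in this assay, within a range from 8000 nM to 80000 nM.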

Compound 3, half-maximal inhibitory concentration: 10000 nM
Estimate against measurement, compound 3: 2.5-fold (0.40 log units) above, and the stated range covers the measured number.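

Putting phenyl in place of phenethyl on a saturated chain carbon, eight bonds along the chain from a carbonyl carbon, gives a 1.4-fold lower number from compound 2 to compound 3 (0.15 log units; within the scatter). Going by these compounds alone, this is the only step that can be read in this assay, and it shows that phenethyl and phenyl cannot be told apart at this position, so this change in chain length leaves the result within the scatter. The remaining entry belongs to compound 1 and is a limit, not a number: the limit of > 100000 nM in this assay, at which 1 of the 3 values shown sits.

Going by these compounds, what stays open is whether a much shorter chain would leave the result equally undisturbed. On these data alone, it is also open whether a carboxylic acid or an amine in place of phenyl would be tolerated at this position in this assay.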